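Swapping the ring-nitrogen acyl group for an aryl sulfonyl

A few compounds are considered here, and "the series" means these few. Any claim that something is new, unique, unknown or untested is made for them only; others in the source may bear on it.

Compounds measured so far:
- compound 1, `Cc1ccc(C(=O)N2N=C(c3ccc(N4CCN(C)CC4)cc3)CC2c2ccc(N(C)C)cc2)cc1`: -0.4%
- compound 2, `CN1CCN(c2ccc(C3=NN(C(=O)c4ccc(C(F)(F)F)cc4)C(c4ccc(N(C)C)cc4)C3)cc2)CC1`: 93.2%
- compound 3, `CN1CCN(c2ccc(C3=NN(S(C)(=O)=O)C(c4ccc(N(C)C)cc4)C3)cc2)CC1`: -1.3%

All three share one core and were tested in a functional assay on NCI-H1975 cells (Homo sapiens) for inhibition, read by sulforhodamine B assay, tested at 10 uM; a lower number here means less inhibition, a higher number more inhibition at the concentration tested (going by the name of the read-out). Compound 2 stands highest of the three numbers; the nearest is compound 1, with a number 93.6 percentage points higher from compound 1 to compound 2 (beyond the scatter), and the furthest is compound 3, with a number 94.5 percentage points lower from compound 2 to compound 3 (beyond the scatter). Compound 1 and compound 3 sit within the scatter of each other, as a number 0.9 percentage points lower from compound 1 to compound 3 (within the scatter) shows.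

The new compound 4, `CN1CCN(c2ccc(C3=NN(S(=O)(=O)c4ccc(C#N)cc4)C(c4ccc(N(C)C)cc4)C3)cc2)CC1`, differs from compound 2 at one place: (4-cyanophenyl)sulfonyl in place of (4-(trifluoromethyl)phenyl)carbonyl on an amine nitrogen in a ring.

For the measured compounds named here, two measured steps bear on this change. The step from compound 2 to compound 3 replaced the aryl carbonyl group with a small sulfonyl group and removed almost all of the inhibition. The step from compound 1 to compound 2 shows that the group on the aromatic ring of that acyl substituent alone decides between no inhibition and strong inhibition. Compound 4 keeps an aromatic ring on the ring nitrogen but attaches it through a sulfonyl group and carries a nitrile in place of the trifluoromethyl group, so neither measured step matches it closely. A drop from compound 2 is therefore expected, of about a number 63.2 percentage points lower from compound 2 to compound 4 (beyond the scatter), with wide uncertainty. For compound 4 the estimated value in this assay is 30%, in the range from -5% to 85%.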

Compound 4, a percentage reported as inhibition, at one concentration (the size of the read-out at that concentration, not a potency): 100%
Compound 4: middle estimate off by 70 percentage points, on the low side; measured number outside the range, above it.
By their numbers in this assay, from the lowest: compounds 3 and 1 (each within the scatter of the next); then compounds 2 and 4 (each within the scatter of the next).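

In this assay, the swap of (4-(trifluoromethyl)phenyl)carbonyl for (4-cyanophenyl)sulfonyl gives a number 6.8 percentage points higher from compound 2 to compound 4 (within the scatter) at this ring nitrogen, so a sulfonyl link here can go with strong inhibition. The near-total loss seen with compound 3 therefore goes with the small methyl on the sulfonyl sulfur and not with the sulfonyl link, as 4-cyanophenyl in place of that methyl gives a number 101.3 percentage points higher from compound 3 to compound 4 (beyond the scatter) in the same assay. An aromatic ring on this nitrogen is still not enough on its own: compound 1 carries one and goes against any such rule, and the replacement of its (4-methylphenyl)carbonyl gives a number 100.4 percentage points higher from compound 1 to compound 4 (beyond the scatter) here.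

Still open, going by these compounds, is whether the nitrile or the sulfonyl link accounts for that last step, a question that a 4-methylphenyl on the sulfonyl or a 4-cyanophenyl on the carbonyl would settle, and whether an amine or a carboxylic acid on the same aromatic ring would keep the inhibition. Nothing measured here explains the size of these steps.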